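Swapping Fluorines for Methoxy Groups on an Amide-Bound Phenyl

The source may hold more compounds than are shown below. What is called first, only, known or untested is meant among the compounds shown, and "the series" means these compounds.

In a functional assay on HT-29 cells (Homo sapiens) for cytotoxicity, read by MTT assay, with a stated time of 72 h (on this read-out higher numbers stand for weaker inhibition and lower numbers for stronger inhibition), three compounds have been measured:
compound 1, `O=C(CN1CCN(c2nnc(Cc3ccncc3)c3ccccc23)CC1)Nc1ccc(F)c(F)c1`, gives 2320 nM
compound 2, `O=C(CN1CCN(c2nnc(Cc3ccncc3)c3ccccc23)CC1)Nc1ccc(Br)cc1`, gives 1990 nM
compound 3, `Cc1ccccc1NC(=O)CN1CCN(c2nnc(Cc3ccncc3)c3ccccc23)CC1`, gives 15000 nM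

Compound 1 stands second highest of these three numbers. Its nearest neighbour is compound 2, with a 1.2-fold lower number from compound 1 to compound 2 (0.07 log units; within the scatter), a difference within the scatter. Its furthest is compound 3, with a 6.5-fold higher number from compound 1 to compound 3 (0.81 log units; beyond the scatter), a modest step beyond the scatter.

Compound 4, `COc1ccc(NC(=O)CN2CCN(c3nnc(Cc4ccncc4)c4ccccc34)CC2)cc1OC`, differs from compound 1 in one place: 3,4-dimethoxyphenyl in place of 3,4-difluorophenyl on an amide-type nitrogen. The step from compound 1 to compound 2 shows that exchanging one phenyl substituent pattern for another at these positions left the number unchanged, while compound 3, with its 2-methylphenyl, weakened. Compound 4 keeps the substitution pattern of compound 1 rather than that of compound 3, so in this assay little change beyond the scatter is expected, perhaps a slight weakening: compound 4 is estimated at 3500 nM, between 1200 nM and 10000 nM, which means an expected 1.5-fold higher number from compound 1 to compound 4 (0.18 log units; within the scatter).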

Compound 4, half-maximal inhibitory concentration: 40100 nM
For compound 4 the middle estimate is 11-fold (1.06 log units) below the measured one, and the stated range ends below it.
By their numbers in this assay, from the lowest: compounds 2 and 1 (each within the scatter of the next); then compound 3; then compound 4.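

This position tolerates less than compounds 1 and 2 suggested: 3,4-dimethoxyphenyl in place of 3,4-difluorophenyl gives a 17-fold higher number from compound 1 to compound 4 (1.24 log units; beyond the scatter) even though the substitution pattern stays the same. Compound 4 also stands apart from the others, with a 20-fold higher number from compound 2 to compound 4 (1.30 log units; beyond the scatter) and a 2.7-fold higher number from compound 3 to compound 4 (0.43 log units; beyond the scatter) here, making it the weakest of the four. No available evidence bears on why this exchange matters so much. The compounds shown leave open whether a phenyl carrying only one methoxy group would behave like compound 4 or compound 1. They also leave open how an amine or a carboxylic acid on that phenyl would fare.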